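A ring exchange on a short-lived compound

This account rests on a few compounds, and the source may have more. Where it says the series, first, only, none or still open, it means among the compounds named here.

In an ADME assay on microsomes from liver (Homo sapiens) for metabolic stability (a lower number here means that the compound disappears faster, a higher number that the compound lasts longer), compound 1 `CC(C)C(c1ncco1)c1ccc(-c2ccc3cccc(F)c3c2)[nH]c1=O` stands lowest at 0.178 h, while compound 3 `CCn1ncc2c(F)cc(-c3ccc(C(CC)(CC)c4nncn4C)c(=O)[nH]3)cc21` gives 2.67 h. Compound 2 `CCn1ncc2c(F)cc(-c3ccc(C(CC)(CC)c4nnc(C)[nH]4)c(=O)[nH]3)cc21` is reported only as a limit, > 3 h. Compound 4 `Cc1nc(C(c2ccc(-c3ccc4cccc(F)c4c3)[nH]c2=O)C(C)C)[nH]c1C` differs from compound 1 in one place: 4,5-dimethyl-1H-imidazol-2-yl in place of 1,3-oxazol-2-yl on a saturated chain carbon bound to an aromatic carbon and a saturated chain carbon. There, 4,5-dimethyl-1H-imidazol-2-yl replaces 1,3-oxazol-2-yl on a saturated chain carbon bound to an aromatic carbon and a saturated chain carbon. The nearest measured step is an at least 1.1-fold lower number from compound 2 to compound 3 (0.05 log units; that floor lies within the scatter), which exchanges other groups on a different core and offers only weak guidance. On that slim basis, the expected step is small, a 1.1-fold lower number from compound 1 to compound 4 (0.05 log units; within the scatter), and no shift beyond the scatter is expected. For compound 4 the estimated half-life is 0.16 h, with an expected range of 0.06 h to 0.45 h.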

Compound 4, half-life: 0.268 h
For compound 4 the middle estimate is 1.7-fold (0.22 log units) below the measured one; the measured number falls inside the stated range.
By their numbers in this assay, from the lowest: compounds 1 and 4 (each within the scatter of the next); then compound 3. At a limit, above all of these: compound 2.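

On this core, 4,5-dimethyl-1H-imidazol-2-yl in place of 1,3-oxazol-2-yl gives in this assay a 1.5-fold higher number from compound 1 to compound 4 (0.18 log units; within the scatter). Going by these compounds alone, two more heavy atoms and a hydrogen-bond donor at this place therefore leave the half-life unresolved from that of the parent, the first reading of a ring exchange on this core. No measured property on hand bears on this step. Still open, as far as these compounds go, is whether a different group at this place, such as an amine or a carboxylic acid, would shift the half-life beyond the scatter.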